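Methyl for methoxy at the anilino ring: step from compound 1

The compounds below may be only part of what the source reports. "The series", "measured", "known", "first", "only" and "open" are said of these compounds alone.

Compound 1 `COc1ccc(Nc2nnc(Cl)c(Nc3cc(OC)c(OC)c(OC)c3)n2)cc1` carries a methoxyphenylamino group on one side of the shared core and a trimethoxyphenylamino group on the other. Going by the values given here, in a functional assay on ECa-109 cells for inhibition, with ECa-109 cell line (Homo sapiens) as the target, read by MTT assay, with a stated time of 48 h (on this read-out lower numbers stand for stronger inhibition and higher numbers for weaker inhibition), compound 1 gives 22300 nM and is the only compound of the pair with a measured number. Compound 2 `COc1cc(Nc2nnc(Cl)c(Nc3cc(OC)c(OC)c(OC)c3)n2)cc(OC)c1OC` carries trimethoxyphenylamino groups on both sides of the same core. In this assay compound 2 reaches only a limit, > 50000 nM, so no number is known for it; that is the limit of > 50000 nM in this assay, at which 1 of the 2 values shown sits. Among the compounds with values here, the two values show that compound 1 is the one that can be followed, as no step between measured compounds is available here.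

Compound 3 `COc1cc(Nc2nc(Nc3ccc(C)cc3)nnc2Cl)cc(OC)c1OC` differs from compound 1 in one place: methyl in place of methoxy on an aromatic carbon. Nothing in the data gives a cause for any effect of this change. The expected step is a 1.0-fold lower number from compound 1 to compound 3 (0.01 log units; within the scatter), that is, none beyond the scatter in this assay. For compound 3 the expected value in this assay is estimated at 22000 nM, with a range from 8000 nM to 50000 nM.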

Compound 3, half-maximal inhibitory concentration: 27300 nM
Estimate against measurement, compound 3: 1.2-fold (0.09 log units) below, and the stated range covers the measured number.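

In this assay, going by these compounds alone, the change from 4-methoxyphenyl to 4-methylphenyl gives a 1.2-fold higher number from compound 1 to compound 3 (0.09 log units; within the scatter), the first step between measured compounds. At this place on the aromatic ring, para to a large group, the oxygen and the hydrogen-bond acceptor of the methoxy group can therefore leave with no change beyond the scatter, so this one exchange does not separate the two groups on this read-out. The data shown give no cause for this result, and nothing else measured here bears on this step.

Going by these compounds, whether a group of a different kind at the same place, such as an amine, a hydroxyl group or a carboxylic acid, would move the number beyond the scatter remains open. Also open is whether the same exchange of methoxy for methyl would behave alike on the trimethoxyphenylamino ring, since the single step shown comes from one place on the shared core.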